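Swapping methoxy for trifluoromethyl on a sulfamide-bearing piperidine

The compounds below may be only part of what the source reports. "The series", "measured", "known", "first", "only" and "open" are said of these compounds alone.

Of the compounds shown here, two sharing one core have been measured in a functional assay on MCF7 cells (Homo sapiens) for antiproliferative activity, read by sulforhodamine B assay, with a stated time of 48 h; a higher number here means a weaker inhibitor of growth, a lower number a stronger inhibitor of growth. Compound 1 `NS(=O)(=O)NCC1CCN(c2cc(-c3ccc(C(F)(F)F)cc3)ncn2)CC1` gives 22500 nM in this assay. Compound 2 `COc1ccc(-c2cc(N3CCC(CCNS(N)(=O)=O)CC3)ncn2)cc1` gives 56600 nM in this assay, the highest number of the two, and its gap to compound 1 lies beyond the usual scatter.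

Compound 3 `NS(=O)(=O)NCCC1CCN(c2cc(-c3ccc(C(F)(F)F)cc3)ncn2)CC1` is the next step. It differs from compound 2 in one place: trifluoromethyl in place of methoxy on an aromatic carbon. After this change compound 3 carries the same trifluoromethyl ring as compound 1 while keeping the longer chain of compound 2.

Because compound 1 gives 22500 nM in this assay with that same trifluoromethyl ring, compound 3 is expected to move to a lower number, by a step of about a 2.3-fold lower number from compound 2 to compound 3 (0.35 log units; beyond the scatter) from the value of compound 2. Compound 3 is therefore estimated at 25000 nM in this assay, within a range from 9000 nM to 70000 nM.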

Compound 3, concentration for 50% growth inhibition: 15200 nM
Beside the measured number, compound 3's estimate is 1.6-fold (0.22 log units) above it, and the stated range covers the measured number.
By their numbers in this assay, from the lowest: compounds 3 and 1 (each within the scatter of the next); then compound 2.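

In this assay, going by these compounds alone, trifluoromethyl in place of methoxy on an aromatic carbon, para to a large group, gives a 3.7-fold lower number from compound 2 to compound 3 (0.57 log units; beyond the scatter) with the chain left unchanged, so this is the first direct reading of the swap at this position. With trifluoromethyl on the ring, (sulfamoylamino)methyl in place of sulfamoylamino on the saturated chain carbon gives a 1.5-fold lower number from compound 1 to compound 3 (0.17 log units; within the scatter) and no difference can be claimed between these two chains. No measurement shown here explains the effect of the ring swap.

Going by these compounds, it remains open whether a chlorine atom, a nitrile or a plain hydrogen at this ring position would track trifluoromethyl or methoxy. A longer chain ahead of the sulfamoylamino group also remains untested by the compounds shown.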